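The source may hold more compounds than are shown below. What is called first, only, known or untested is meant among the compounds shown, and "the series" means these compounds.

Compound 2 `O=C(NCCNS(=O)(=O)c1ccc(-c2ccccc2Oc2ccc([N+](=O)[O-])c([N+](=O)[O-])c2)s1)Nc1ccc([N+](=O)[O-])cc1` is the starting point. In a functional assay on HeLa cells (Homo sapiens) for inhibition, read by CCK-8 assay, with a stated time of 48 h (a higher number here means a weaker inhibitor, a lower number a stronger inhibitor), compound 2 reaches only a limit of the assay, > 20000 nM. Compound 1 `Cc1cc(C)cc(NC(=O)NCCNS(=O)(=O)c2ccc(-c3ccccc3Oc3ccc([N+](=O)[O-])c([N+](=O)[O-])c3)s2)c1` carries 3,5-dimethylphenyl on an amide-type nitrogen where compound 2 carries 4-nitrophenyl; in this assay compound 1 gives 12000 nM. For the measured compounds named here, the single measured step, an at least 1.6-fold higher number from compound 1 to compound 2 (0.22 log units; that floor lies within the scatter), is bounded by the limit of > 20000 nM in this assay, at which 1 of the 2 values shown sits, so the true distance between the two compounds stays open. Compound 3 `COc1ccc(NC(=O)NCCNS(=O)(=O)c2ccc(-c3ccccc3Oc3ccc([N+](=O)[O-])c([N+](=O)[O-])c3)s2)cc1` differs from compound 2 in one place: methoxy in place of nitro on an aromatic carbon. Going by the values given here, no measured step covers a change of nitro to methoxy, so the expectation rests only on how weakly both measured compounds inhibit. For compound 3 the expected result in this assay is 15000 nM, with a range from 5000 nM to 40000 nM. That estimate means a step of an at least 1.3-fold lower number from compound 2 to compound 3 (0.12 log units; that floor lies within the scatter), expected to be small, and a reported limit rather than a number remains quite possible.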

Compound 3, half-maximal inhibitory concentration: > 20000 nM
Compound 3 ended at the assay's limit; the forecaster's own chance of this, stated with the estimate: 45%; middle value at least 1.3-fold (0.12 log units) away from the limit.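

With methoxy in place of nitro, compound 3 in this assay gives > 20000 nM, which is a limit and not a number, as is the value of compound 2. The step between these two cannot be read, so the change from nitro to methoxy at this position, para to a large group, has no measurable size here, and neither group yields a readable number. The comparison with 3,5-dimethylphenyl gives only a floor, an at least 1.6-fold higher number from compound 1 to compound 3 (0.22 log units; that floor lies within the scatter), and the series now rests mostly on one ceiling: the limit of > 20000 nM in this assay, at which 2 of the 3 values shown sit.

Going by these compounds, how far compound 2 and compound 3 lie beyond that limit remains open. Also open, on these data alone, is whether an amine or a carboxylic acid at this position would give a readable number.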